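The compounds below may be only part of what the source reports. "The series", "measured", "known", "first", "only" and "open" are said of these compounds alone.

In a functional assay on the whole organism for inhibition, with Cavia porcellus as the target (on this read-out higher numbers stand for an effect only at larger amounts of compound and lower numbers for an effect already at smaller amounts), compound 2 `COc1ccccc1OCC1SCCN1C(=O)Cn1ccnc1` gives 50 mg/kg. That is within the scatter of compound 3 `COc1ccc(OCC2SCCN2C(=O)Cn2ccnc2)cc1` at 48 mg/kg and of compound 1 `COc1ccccc1OCC1SCCN1C(=O)C[S+](C)[O-]` at 25 mg/kg. The next structure is compound 4 `COc1ccccc1OCC1SCCN1C(=O)CC(=O)O`, and the change is carboxy in place of 1H-imidazol-1-yl on a saturated chain carbon bound to a carbonyl carbon. Among the measured compounds shown here, only one measured step bears on this place, a 2.0-fold higher number from compound 1 to compound 2 (0.30 log units; within the scatter), and it stayed within the scatter. For the measured compounds named here, no carboxy compound has been measured yet, so this evidence is indirect. The expected change, a 1.3-fold lower number from compound 2 to compound 4 (0.10 log units; within the scatter), is therefore none beyond the scatter, in either direction. For compound 4 the estimated value is 40 mg/kg, with an expected range of 15 mg/kg to 110 mg/kg.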

Compound 4, dose for half-maximal effect: 20 mg/kg
Beside the measured number, compound 4's estimate is 2.0-fold (0.30 log units) above it; low and high end bracket the measured number.
By their numbers in this assay, from the lowest: compounds 4, 1, 3 and 2 (each within the scatter of the next, the first and the last beyond it).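

With carboxy on the saturated chain carbon bound to a carbonyl carbon, this position gives its first step beyond the scatter in this assay, a modest one: a 2.5-fold lower number from compound 2 to compound 4 (0.40 log units; beyond the scatter). The group carried here can therefore shift the number, which the earlier step at this place had not shown. Carboxy stays close to the group of compound 1: a 1.3-fold lower number from compound 1 to compound 4 (0.10 log units; within the scatter).

Nothing shown accounts for the step. On these data alone, whether an amine, an ester or a longer chain ending in carboxy would shift the number further remains open, as does the effect of carboxy on the core of compound 3.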